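The source may hold more compounds than are shown below. What is called first, only, known or untested is meant among the compounds shown, and "the series" means these compounds.

Measured in an ADME assay on LLC-MK2 cells (Macaca mulatta) for cytotoxicity, read by MTT assay, with a stated time of 48 h; a higher number here means that more compound is tolerated, a lower number that less compound is tolerated:
- compound 1 `COc1ccc(/C=C/C(=O)/C(C)=C/c2ccccc2)cc1` gives 93000 nM
- compound 2 `COc1ccc(/C=C/C(=O)/C(C)=C/c2ccc(OC)cc2)cc1` gives 75000 nM
- compound 3 `C/C(=C\c1ccc([N+](=O)[O-])cc1)C(=O)/C=C/c1ccccc1` gives 264000 nM

Compound 3 has the highest number of the three, beyond the scatter from both compound 1 and compound 2. Compound 4 `COc1ccc(/C=C/C(=O)/C(C)=C/c2ccc([N+](=O)[O-])cc2)cc1` carries methoxy in place of hydrogen on an aromatic carbon, para to a large group methoxy in place of hydrogen on an aromatic carbon and otherwise matches compound 3. Within the data shown here, only one measured step bears on this replacement: a 1.2-fold lower number from compound 1 to compound 2 (0.09 log units; within the scatter). That step was measured without the nitro group of compound 3, so it is only a loose guide. No step beyond the scatter is expected in this assay, and the estimated change is a 1.3-fold lower number from compound 3 to compound 4 (0.12 log units; within the scatter). For compound 4 the estimated value is 200000 nM, with an expected range of 90000 nM to 400000 nM.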

Compound 4, half-maximal cytotoxic concentration: 172000 nM
Estimate against measurement, compound 4: 1.2-fold (0.07 log units) above; the range from low to high includes it.
By their numbers in this assay, from the lowest: compounds 2, 1, 4 and 3 (each within the scatter of the next, the first and the last beyond it).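

In this assay, methoxy in place of hydrogen on an aromatic carbon now reads on a second core, giving a 1.5-fold lower number from compound 3 to compound 4 (0.19 log units; within the scatter). The outcome is the same small one on both cores: the same change on two cores in this assay, a 1.2-fold lower number (0.09 log units; within the scatter) from compound 1 to compound 2 and a 1.5-fold lower number (0.19 log units; within the scatter) from compound 3 to compound 4, 1.2-fold (0.09 log units) apart, within the scatter of two such steps. The nitro group can now be compared on the methoxy-bearing core: nitro in place of methoxy gives a 2.3-fold higher number from compound 2 to compound 4 (0.36 log units; beyond the scatter), while nitro in place of hydrogen gives a 1.8-fold higher number from compound 1 to compound 4 (0.27 log units; within the scatter). Only the first of these two steps lies beyond the scatter.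

From the compounds shown here alone, whether an amine or a carboxylic acid at this place would give a step beyond the scatter remains open. The reason for the nitro step also remains open.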